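A few compounds are considered here, and "the series" means these few. Any claim that something is new, unique, unknown or untested is made for them only; others in the source may bear on it.

Compound 1 `CN(C)c1ccc(-c2ccc(-c3ccc(-c4nc5ccccc5[nH]4)cc3)cc2)cc1` gives 100000 nM
Compound 2 `Oc1ccc(-c2ccc(-c3ccc(-c4nc5c(O)cccc5[nH]4)cc3)cc2)cc1` gives 2700 nM

In a functional assay on DWD cells (Homo sapiens) for inhibition, read by sulforhodamine B assay (a higher number here means a weaker inhibitor of growth, a lower number a stronger inhibitor of growth), compound 2 holds the lower of the two numbers, and the gap up to compound 1 lies beyond the scatter. Of this pair, compound 2 is therefore the stronger inhibitor of growth. Compound 3 `CN(C)c1ccc(-c2ccc(-c3ccc(-c4nc5c(O)cccc5[nH]4)cc3)cc2)cc1` differs from compound 2 in one place, with dimethylamino in place of hydroxy on an aromatic carbon, para to a large group (dimethylamino in place of hydroxy on an aromatic carbon). Going by the values given here, no measured pair shows this swap on its own. Compound 2, with hydroxy, gives 2700 nM while compound 1, with dimethylamino, gives 100000 nM but those two compounds differ in more than one place, so their gap cannot be laid on this swap alone. A rise in the number is expected, meaning a weaker inhibitor of growth, with a 4.4-fold higher number from compound 2 to compound 3 (0.65 log units; beyond the scatter) as the estimated step, beyond the scatter yet short of the whole gap. The estimate for compound 3 is 12000 nM with an expected range of 3500 nM to 45000 nM (not yet measured).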

Compound 3, concentration for 50% growth inhibition: 9210 nM
Compound 3: middle estimate off by 1.3-fold (0.11 log units), on the high side; the measured number falls inside the stated range.
By their numbers in this assay, from the lowest: compound 2; then compound 3; then compound 1.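

The swap of hydroxy for dimethylamino can now be read on its own in this assay and, going from 4-hydroxyphenyl to 4-(dimethylamino)phenyl, gives a 3.4-fold higher number from compound 2 to compound 3 (0.53 log units; beyond the scatter) as a modest loss of growth inhibition. Compound 3 also isolates the other difference in the series. Hydroxy in place of hydrogen on an aromatic carbon gives an 11-fold lower number from compound 1 to compound 3 (1.04 log units; beyond the scatter) as a large gain in growth inhibition. The wide gap between compound 1 and compound 2 therefore splits into two single changes, and both matter, with the hydroxy that compound 2 and compound 3 share making the larger step.

Nothing here shows why either change moves the number. Going by these compounds, it also remains open how other groups would behave in these two places, for example methoxy or a plain amine in place of the dimethylamino, or fluorine in place of the hydroxy on the shared core.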